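A Benzyloxy Swap Tested on a Longer Chain

The compounds below may be only part of what the source reports. "The series", "measured", "known", "first", "only" and "open" are said of these compounds alone.

Compound 1 `CO/N=c1\[nH]cnc2c1[n+](C/C=C(\C)CC/C=C(/C)CCC=C(C)C)cn2C` and compound 2 `CC(C)=CCC/C(C)=C\CC/C(C)=C/C[n+]1cn(C)c2nc[nH]/c(=N\OCc3ccccc3)c21` share a charged core and a chain of the same length. In a functional assay on CEM/s cells (Homo sapiens) for cytotoxicity (a lower number here means a stronger inhibitor, a higher number a weaker inhibitor), compound 1 gives 1230 nM and compound 2 gives 10000 nM. Within the data shown here, the single change between them, (phenyl in place of hydrogen on a saturated chain carbon bound to an oxygen), gave an 8.1-fold higher number from compound 1 to compound 2 (0.91 log units; beyond the scatter). Compound 3 `CO/N=c1\[nH]cnc2ncn(C/C=C(\C)CC/C=C(\C)CC/C=C(\C)CCC=C(C)C)c12` carries a longer chain on a core without that charge; the difference between its core and the core of compound 1 is not broken down here. In this assay compound 3 gives 5690 nM, a number that lies within the scatter of compound 2 and beyond the scatter of compound 1.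

Compound 4 `CC(C)=CCC/C(C)=C/CC/C(C)=C/CC/C(C)=C/Cn1cnc2nc[nH]/c(=N\OCc3ccccc3)c21` is the unmeasured member of the set. It differs from compound 3 by phenyl in place of hydrogen on a saturated chain carbon bound to an oxygen, the same change that turned compound 1 into compound 2, at the same place on the chain. Nothing else is altered, so the expectation for compound 4 in this assay rests on that single earlier step. The number is expected to rise by a 4.4-fold higher number from compound 3 to compound 4 (0.64 log units; beyond the scatter), set a little below the full size of an 8.1-fold higher number from compound 1 to compound 2 (0.91 log units; beyond the scatter), since that step rests on one pair only and compound 3 already starts at 5690 nM. Compound 4 is therefore estimated at 25000 nM, with a likely range from 8000 nM to 80000 nM.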

Compound 4, half-maximal inhibitory concentration: 20400 nM
Estimate against measurement, compound 4: 1.2-fold (0.09 log units) above; the measured number falls inside the stated range.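

On the core of compound 3, going from methoxy to benzyloxy again made the compound a weaker inhibitor in this assay, with a 3.6-fold higher number from compound 3 to compound 4 (0.55 log units; beyond the scatter) as the new step. Both pairs therefore moved in the same direction, and the sizes of their steps cannot be told apart: the same change on two cores in this assay, an 8.1-fold higher number (0.91 log units; beyond the scatter) from compound 1 to compound 2 and a 3.6-fold higher number (0.55 log units; beyond the scatter) from compound 3 to compound 4, 2.3-fold (0.36 log units) apart, within the scatter of two such steps. Among these compounds, this shows only that the change carried over between these two cores; two pairs do not make a general rule, and they cannot show that the step would keep its direction or size on any further core, nor whether the charge or the chain length of the core has any bearing on it.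

The compounds shown leave open how the shorter chain would behave on the uncharged core and the longer chain on the charged core, two pairings that would separate the two ways in which these cores differ. They also leave open what would happen with other groups on the oxygen, such as an ethyl group or a benzyl group whose ring carries an amine or a carboxylic acid.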